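The source may hold more compounds than are shown below. What is called first, only, known or untested is meant among the compounds shown, and "the series" means these compounds.

Working notes on the series, read in a functional assay on the whole organism for inhibition, with Cavia porcellus as the target; a higher number here means that more compound is needed for the effect, a lower number that less compound is needed. Compound 1 `COc1ccccc1OCC1SCCN1C(=O)C[S+](C)[O-]` gives 25 mg/kg. Compound 2 `CCOC(=O)CC(=O)N1CCSC1COc1ccccc1O` gives 20 mg/kg, and compound 3 `COc1ccccc1OCC1SCCN1C(=O)CC(=O)O` gives 20 mg/kg, level with compound 2 and within the scatter of compound 1. The next change leads to compound 4 `O=C(O)CC(=O)N1CCSC1COc1ccccc1O`: hydrogen in place of methyl on an oxygen on an aromatic ring, methoxy to hydroxy. For the measured compounds named here, the only measured step, a 1.3-fold lower number from compound 1 to compound 3 (0.10 log units; within the scatter), lies at another place in the molecule and does not test this change. Compound 2 also carries the hydroxy but differs elsewhere too, and it stands at 20 mg/kg. The data therefore give no reason to expect a shift beyond the scatter. The expected result is no change at the digits printed from compound 3 to compound 4 (within the scatter). Compound 4 is estimated at 20 mg/kg, with an expected range of 8 mg/kg to 45 mg/kg.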

Compound 4, dose for half-maximal effect: 25 mg/kg
Compound 4: middle estimate off by 1.3-fold (0.10 log units), on the low side; measured number inside the range.
By their numbers in this assay, from the lowest: compounds 2, 3, 1 and 4 (each within the scatter of the next).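

In this assay methoxy to hydroxy on the aromatic ring now has a direct reading, a 1.3-fold higher number from compound 3 to compound 4 (0.10 log units; within the scatter), so at this position the two groups cannot be told apart. Hydrogen in place of ethyl on an oxygen next to a carbonyl group gives a 1.3-fold higher number from compound 2 to compound 4 (0.10 log units; within the scatter), so that place also shows no step beyond the scatter. No measurement shown here offers an explanation for either reading. As far as these compounds go, whether a benzyl group on the oxygen on the aromatic ring, or an amine in place of that oxygen, would move the number beyond the scatter remains open.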